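Swapping anilino for benzylamino on the shared core

A few compounds are considered here, and "the series" means these few. Any claim that something is new, unique, unknown or untested is made for them only; others in the source may bear on it.

Values measured in an assay on isolated protein for inhibition of serine/threonine-protein kinase PAK 4 (Homo sapiens), read by HTRF, with a stated time of 60 min; a lower number here means a stronger inhibitor, a higher number a weaker inhibitor:
Compound 1 `Cc1cc(Nc2nc(Cl)nc3[nH]ncc23)n[nH]1`: 5940 nM
Compound 2 `Cc1cc(Nc2nc(NC3CCNC3)nc3[nH]ncc23)n[nH]1`: 1050 nM
Compound 3 `Cc1cc(Nc2nc(Nc3ccccc3)nc3[nH]ncc23)n[nH]1`: 5900 nM

Among these three numbers, compound 3 gives the second highest. The step of a 1.0-fold lower number from compound 1 to compound 3 (0.00 log units; within the scatter) is within the usual scatter, so compound 1 and compound 3 are not distinguishable here. The step of a 5.6-fold higher number from compound 2 to compound 3 (0.75 log units; beyond the scatter) is beyond the scatter and marks the only real separation in the set.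

Compound 4 `Cc1cc(Nc2nc(NCc3ccccc3)nc3[nH]ncc23)n[nH]1` has not been measured in this assay. It differs from compound 3 in one place: benzyl in place of phenyl on a nitrogen on an aromatic ring. Among the compounds with values here, two measured steps bear on this. The step of a 5.7-fold lower number from compound 1 to compound 2 (0.75 log units; beyond the scatter) shows that a saturated ring amine in place of chloro lowers the number modestly, and the step of a 5.6-fold higher number from compound 2 to compound 3 (0.75 log units; beyond the scatter) shows that phenyl on that nitrogen returns it to where chloro stood. Benzyl keeps the six-membered aromatic ring of phenyl and adds one carbon, so no measured step covers this exact exchange. A small lowering is expected in this assay, possibly no larger than the scatter.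

Compound 4 is therefore estimated at 3000 nM, with a range from 1000 nM to 9000 nM. The expected step is a 2.0-fold lower number from compound 3 to compound 4 (0.29 log units; within the scatter).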

Compound 4, half-maximal inhibitory concentration: 1960 nM
Estimate against measurement, compound 4: 1.5-fold (0.18 log units) above; the range from low to high includes it.
By their numbers in this assay, from the lowest: compounds 2 and 4 (each within the scatter of the next); then compounds 3 and 1 (each within the scatter of the next).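

In this assay, one added carbon is enough to separate two compounds that both carry a six-membered aromatic ring of carbon only on this nitrogen: the exchange of phenyl for benzyl gives a 3.0-fold lower number from compound 3 to compound 4 (0.48 log units; beyond the scatter), a step beyond the scatter. An aromatic ring on this nitrogen therefore does not by itself leave the number where chloro stood, for anilino could not be told apart from chloro, whereas benzylamino gives a 3.0-fold lower number from compound 1 to compound 4 (0.48 log units; beyond the scatter). A saturated ring amine is also no longer the only group shown to lower the number, and a 1.9-fold higher number from compound 2 to compound 4 (0.27 log units; within the scatter) lies within the scatter, so pyrrolidin-3-yl and benzyl on this nitrogen cannot be told apart here.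

No measurement at hand explains why one carbon changes the number in this way.

The compounds shown leave open whether a longer chain, such as phenethyl, would lower the number further or raise it again, and whether a fluorine or a methoxy group on the ring of the benzyl group would shift it.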